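Swapping the furan for a phenylethenyl group

The compounds below may be only part of what the source reports. "The series", "measured", "known", "first", "only" and "open" are said of these compounds alone.

Compounds measured in a functional assay on HCT-116 cells (Homo sapiens) for antiproliferative activity, with a stated time of 72 h; a higher number here means a weaker inhibitor, a lower number a stronger inhibitor:
- Compound 1 `CCCC#Cc1cc([C@@H]2O[C@H](CO)[C@@H](O)[C@H]2O)n2ncnc(N)c12`: 200 nM
- Compound 2 `Nc1ncnn2c([C@@H]3O[C@H](CO)[C@@H](O)[C@H]3O)cc(C#Cc3ccccc3)c12`: 46900 nM
- Compound 3 `Nc1ncnn2c([C@@H]3O[C@H](CO)[C@@H](O)[C@H]3O)cc(-c3ccoc3)c12`: 1400 nM

Compound 3 holds the middle place of the three numbers, with a 7.0-fold higher number from compound 1 to compound 3 (0.85 log units; beyond the scatter) and a 34-fold lower number from compound 2 to compound 3 (1.53 log units; beyond the scatter). Compound 4 `Nc1ncnn2c([C@@H]3O[C@H](CO)[C@@H](O)[C@H]3O)cc(/C=C/c3ccccc3)c12` has 2-phenylethenyl in place of furan-3-yl on an aromatic carbon. The closest guide is compound 2, whose 2-phenylethynyl group also ends in a phenyl ring. That group accompanied large losses, seen in a 230-fold higher number from compound 1 to compound 2 (2.37 log units; beyond the scatter) and in the reverse of a 34-fold lower number from compound 2 to compound 3 (1.53 log units; beyond the scatter). A double bond is not a triple bond, so only part of that loss is expected in this assay. The estimate is an 8.6-fold higher number from compound 3 to compound 4 (0.93 log units; beyond the scatter), a clear rise in the number. Compound 4 is expected at about 12000 nM, with an estimated range of 2500 nM to 50000 nM.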

Compound 4, half-maximal inhibitory concentration: 4800 nM
Beside the measured number, compound 4's estimate is 2.5-fold (0.40 log units) above it; the measured number falls inside the stated range.
By their numbers in this assay, from the lowest: compound 1; then compound 3; then compound 4; then compound 2.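

In this assay a phenyl ring at this position costs less when it is held by a double bond than by a triple bond, with a 9.8-fold lower number from compound 2 to compound 4 (0.99 log units; beyond the scatter). Even so, the 2-phenylethenyl group remains behind furan-3-yl, with a 3.4-fold higher number from compound 3 to compound 4 (0.54 log units; beyond the scatter), and further behind pent-1-yn-1-yl, with a 24-fold higher number from compound 1 to compound 4 (1.38 log units; beyond the scatter). Nothing measured here explains these differences. The compounds shown leave open how a saturated two-carbon link to the phenyl ring would compare with the double bond. They also leave open whether a longer chain on the triple bond, or an amine at the end of that chain, would improve on pent-1-yn-1-yl.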